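A few compounds are considered here, and "the series" means these few. Any claim that something is new, unique, unknown or untested is made for them only; others in the source may bear on it.

Measured so far:
compound 1, `COc1cc(-c2cc(C(=O)O)c3ccccc3n2)ccc1OCC(=O)Nc1cccc(F)c1`, 148000 nM
compound 2, `COc1cc(-c2cc(C(=O)O)c3ccccc3n2)ccc1OCC(=O)Nc1ccccc1C(F)(F)F`, 102000 nM

Both compounds were tested in an ADME assay on HaCaT cells (Homo sapiens) for inhibition; a lower number here means a stronger inhibitor, a higher number a weaker inhibitor. Compound 1 gives 148000 nM in this assay, and compound 2 gives 102000 nM. Within the data shown here, the only step between them, a 1.5-fold lower number from compound 1 to compound 2 (0.16 log units; within the scatter), lies within the scatter, so compound 2 holds the lowest of the two numbers without standing apart from compound 1 in any meaningful way.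

Compound 3, `CCCCCCNC(=O)COc1ccc(-c2cc(C(=O)O)c3ccccc3n2)cc1OC`, has not yet been measured. It differs from compound 2 by hexyl in place of 2-(trifluoromethyl)phenyl on an amide-type nitrogen. Among the measured compounds shown here, no measured step touches a change of this kind: the one step in hand swaps one aromatic ring for another on the same amide-type nitrogen and moves the number only within the scatter. An open-chain hexyl group in place of an aromatic ring is a larger departure, and the data give no direction for it. The expectation is therefore a step of a 1.4-fold higher number from compound 2 to compound 3 (0.14 log units; within the scatter), no more than the scatter allows, with the uncertainty wide on both sides. Compound 3 is expected to give 140000 nM in this assay, within a range from 45000 nM to 420000 nM.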

Compound 3, half-maximal inhibitory concentration: > 300000 nM
Compound 3 was reported as a limit; the forecaster's own chance of this, stated with the estimate: 25%; middle value at least 2.1-fold (0.33 log units) away from the limit.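

In this assay, compound 3 is reported as a limit and not as a number: the limit of > 300000 nM in this assay, at which 1 of the 3 values shown sits.

Even so, hexyl on the amide-type nitrogen gives the first step in this set that clears the scatter, an at least 2.9-fold higher number from compound 2 to compound 3 (0.46 log units; beyond the scatter), whereas exchanging one aromatic group for another there gave only a 1.5-fold lower number from compound 1 to compound 2 (0.16 log units; within the scatter). The second comparison is less firm, at an at least 2.0-fold higher number from compound 1 to compound 3 (0.30 log units; that floor lies within the scatter), so the floor of this step does not by itself separate hexyl from 3-fluorophenyl. Together, these steps show that the group on this nitrogen can shift the number measurably when an open chain replaces 2-(trifluoromethyl)phenyl, although the full size of that shift stays hidden behind the limit.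

The compounds shown leave open how far compound 3 really lies from the other two, and whether the loss of the aromatic ring or the presence of the chain matters more. A cyclohexyl group on the same nitrogen could separate those two readings, while a shorter butyl chain, or a hexyl chain ending in an amine or a carboxylic acid, could show whether the chain itself can be changed without the same shift.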